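Replacing the dimethoxyphenyl amine with a dichlorophenyl amine

The compounds below may be only part of what the source reports. "The series", "measured", "known", "first", "only" and "open" are said of these compounds alone.

Measured so far in a functional assay on CWR22R cells (Homo sapiens) for inhibition, with a stated time of 120 h, tested at 10 uM; a lower number here means less inhibition, a higher number more inhibition at the concentration tested (going by the name of the read-out):
compound 1 `Cc1n[nH]c2ccc(-c3nc4cnc(N5CCN(C)CC5)cn4c3Nc3ccccc3F)cc12` gives 0%
compound 2 `Cc1n[nH]c2ccc(-c3nc4cnc(N5CCN(C)CC5)cn4c3Nc3ccc(Br)cc3Cl)cc12` gives "not determined" (no result reported)
compound 3 `COc1ccc(Nc2c(-c3ccc4[nH]nc(C)c4c3)nc3cnc(N4CCN(C)CC4)cn23)cc1OC` gives 0%

Compound 3 stands level with compound 1 at the digits reported; the two sit together at the bottom of the scale, and compound 2 offers no single number to compare. Going by the values given here, the one step between measured compounds that differ in one place, from compound 1 to compound 3, reads no change at the digits printed from compound 1 to compound 3 (within the scatter), so exchanging the aryl group on the ring nitrogen once left the read-out where it was.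

The next compound, compound 4 `Cc1n[nH]c2ccc(-c3nc4cnc(N5CCN(C)CC5)cn4c3Nc3ccc(Cl)cc3Cl)cc12`, is reached from compound 3 by a change at the same position: 2,4-dichlorophenyl in place of 3,4-dimethoxyphenyl on a nitrogen on an aromatic ring. Among the compounds with values here, the only step that bears on this position is the one from compound 1 to compound 3, and it was flat within the scatter. Compound 2, which carries a related halogenated aryl group at that position, gives no number to lean on. On this basis the step from compound 3 to compound 4 is expected to be a number 5 percentage points higher from compound 3 to compound 4 (within the scatter), that is, nothing beyond the scatter. Compound 4 is therefore estimated at 5% in this assay, with a range from 0% to 25%.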

Compound 4, a percentage reported as inhibition, at one concentration (the size of the read-out at that concentration, not a potency): 9.53%
Beside the measured number, compound 4's estimate is 4.5 percentage points below it; the range from low to high includes it.
By their numbers in this assay, from the lowest: compounds 1, 3 and 4 (each within the scatter of the next).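

Going by these compounds alone, the earlier compounds showed only that one exchange of aryl groups on this nitrogen left the read-out unmoved, and both of those compounds sat at zero. Compound 4 extends that picture to a halogenated aryl group with two chlorine atoms and to the loss of both hydrogen-bond acceptors of the 3,4-dimethoxyphenyl group: in this assay this exchange gave a number 9.5 percentage points higher from compound 3 to compound 4 (within the scatter), and the comparison with the 2-fluorophenyl group gave a number 9.5 percentage points higher from compound 1 to compound 4 (within the scatter), so all three aryl groups at this position remain within the scatter of one another and none of the steps amounts to a real difference. Nothing measured here speaks to what lies behind these readings.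

The compounds shown leave open whether any group on this nitrogen can lift the inhibition beyond the scatter, since all the readable examples are substituted phenyl rings. A phenyl ring carrying a carboxylic acid or a dimethylamino group, or a cyclohexyl ring in place of the aryl group, would test that question in this assay.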